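Growing the Sulfonamide Substituent: From Compound 3 to Compound 4

This account rests on a few compounds, and the source may have more. Where it says the series, first, only, none or still open, it means among the compounds named here.

Three compounds share one core and differ only in the group on a sulfonyl sulfur. Compound 1 `Cc1ccc(S(=O)(=O)Cc2ccccc2)cc1C#Cc1cc(Cl)ccc1OCC(=O)O` carries a benzyl there and gives 5 nM in an assay on CHO cells for displacement of a labelled ligand from prostaglandin D2 receptor 2 (Homo sapiens), read by scintillation counting; on this read-out lower numbers stand for stronger inhibition and higher numbers for weaker inhibition. Compound 2 `Cc1ccc(S(=O)(=O)N2CCN(C)CC2)cc1C#Cc1cc(Cl)ccc1OCC(=O)O` carries a 4-methylpiperazin-1-yl and gives 21 nM in this assay. Compound 3 `Cc1ccc(S(=O)(=O)N(C)C)cc1C#Cc1cc(Cl)ccc1OCC(=O)O` carries a dimethylamino and gives 5 nM in this assay.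

Swapping benzyl for the cyclic amine is a 4.2-fold higher number from compound 1 to compound 2 (0.62 log units; beyond the scatter); swapping benzyl for dimethylamino is no change at the digits printed from compound 1 to compound 3 (within the scatter); swapping the cyclic amine for dimethylamino is a 4.2-fold lower number from compound 2 to compound 3 (0.62 log units; beyond the scatter). Compound 3 therefore stands level with compound 1, and together they hold the lowest numbers of the three, with compound 2 the furthest away.

Compound 4 `Cc1ccc(S(=O)(=O)N(C)CC(C)C)cc1C#Cc1cc(Cl)ccc1OCC(=O)O` is the next step: isopropyl in place of hydrogen on a saturated chain carbon bound to a sulfonamide nitrogen, so the dimethylamino becomes an isobutyl(methyl)amino. Among the measured compounds shown here, no measured step enlarges a sulfonamide nitrogen substituent in this way. For the measured compounds named here, the steps that bear on it are the changes at the sulfonyl sulfur, which ranged from no change to a modest shift, and none pushed the number far. The expected outcome in this assay is therefore a small step, if any, and the direction is uncertain.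

Compound 4 is estimated at 6 nM, within 2.5 nM to 15 nM, which would mean a 1.2-fold higher number from compound 3 to compound 4 (0.08 log units; within the scatter) as an expected change.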

Compound 4, inhibition constant: 4.2 nM
Compound 4: middle estimate off by 1.4-fold (0.15 log units), on the high side; measured number inside the range.
By their numbers in this assay, from the lowest: compounds 4, 1 and 3 (each within the scatter of the next); then compound 2.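

In this assay, among the compounds shown here, isopropyl in place of hydrogen on a saturated chain carbon bound to a sulfonamide nitrogen gives a 1.2-fold lower number from compound 3 to compound 4 (0.08 log units; within the scatter) and so provides the first direct look at enlarging a substituent on this nitrogen: 3 more carbon atoms, with the step staying inside the scatter. The isobutyl(methyl)amino group also reads level with the benzyl group, with a 1.2-fold lower number from compound 1 to compound 4 (0.08 log units; within the scatter) as the step between them, so three different groups on the sulfonyl sulfur now share the same band of numbers. Only the 4-methylpiperazin-1-yl group stands apart, with a 5.0-fold lower number from compound 2 to compound 4 (0.70 log units; beyond the scatter) as the step away from it, and no measurement shown here explains why these groups differ or match.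

The compounds shown leave open whether this position would accept a longer chain, a phenyl ring or a carboxylic acid at the end of the isobutyl chain as readily as it accepts isobutyl. They also leave open what happens when the remaining methyl on the sulfonamide nitrogen is replaced by hydrogen or by ethyl.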